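An amide's step toward the urea, expected inhibition

This account rests on a few compounds, and the source may have more. Where it says the series, first, only, none or still open, it means among the compounds named here.

The set rests on a shared core, carried by compound 1 `COc1cc(-c2nn(-c3cccc(NC(=O)c4cccc(C(F)(F)F)c4)c3)cc2-c2ccncc2)ccc1Cl` and compound 2 `O=C(Nc1cccc(-n2cc(-c3ccncc3)c(-c3ccc(Cl)c(O)c3)n2)c1)Nc1cc(C(F)(F)F)cc(C(F)(F)F)c1`, together with the not yet measured compound 3 `COc1cc(-c2nn(-c3cccc(NC(=O)Nc4ccc(Cl)c(C(F)(F)F)c4)c3)cc2-c2ccncc2)ccc1Cl`. In a functional assay on PC-3 cells (Homo sapiens) for inhibition, read by sulforhodamine B assay, with a stated time of 48 h (on this read-out higher numbers stand for weaker inhibition of growth and lower numbers for stronger inhibition of growth), compound 1 gives 1230 nM, the higher of the two numbers recorded so far. In this assay compound 2 gives 319 nM, a lower number, and the two values lie beyond the scatter of each other. Compound 2 differs from compound 1 in more than one place, so only the two values themselves can be set side by side.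

The step from compound 1 to compound 3 is a single change: (4-chloro-3-(trifluoromethyl)phenyl)amino in place of 3-(trifluoromethyl)phenyl on a carbonyl carbon. The rest of compound 1 is kept. Among the measured compounds shown here, no step of this kind between two measured compounds is available, so the expectation rests on the two values alone. Compound 3 is expected to move in the direction of compound 2, because compound 2 gives 319 nM. The expected step of a 2.7-fold lower number from compound 1 to compound 3 (0.44 log units; beyond the scatter) is toward stronger inhibition of growth. Compound 3 is estimated at 450 nM, with a range from 130 nM to 1600 nM.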

Compound 3, concentration for 50% growth inhibition: 690 nM
The estimate for compound 3 lay 1.5-fold (0.19 log units) below the measured number; low and high end bracket the measured number.
By their numbers in this assay, from the lowest: compound 2; then compounds 3 and 1 (each within the scatter of the next).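

Among the compounds shown here, the single change at this position, (4-chloro-3-(trifluoromethyl)phenyl)amino in place of 3-(trifluoromethyl)phenyl on a carbonyl carbon, gives in this assay a 1.8-fold lower number from compound 1 to compound 3 (0.25 log units; within the scatter), the first step in this set that can be read at one place. It shows that this position accepts the larger group, with its added nitrogen, chlorine and hydrogen-bond donor, yet compound 1 and compound 3 cannot be told apart in this assay. No measurement in hand offers an explanation for this outcome.

The nitrogen and the chlorine enter together in this one step, so the compounds shown leave open what each contributes alone, which a pair holding only one of them on the same carbonyl carbon could separate. They also leave open how the shared core reads in this assay when this position carries a different group altogether, such as a morpholine or a carboxylic acid on the aromatic ring in place of the chlorine.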